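The source may hold more compounds than are shown below. What is called first, only, known or untested is meant among the compounds shown, and "the series" means these compounds.

Compound 1 `c1ccc2c(c1)CN[C@@H](CN(CCCCNCc1ccncc1)[C@H]1CCCc3cccnc31)C2`: 22.7 nM
Compound 2 `c1ccc2c(c1)CN[C@@H](CN(CCCCNCC1CCSCC1)[C@H]1CCCc3cccnc31)C2`: 69.6 nM

In a functional assay on cells for antagonist activity at C-X-C chemokine receptor type 4 (Homo sapiens), read by fluorescence and calcium flux, with stated times of 25 min and 90 s (on this read-out lower numbers stand for stronger inhibition and higher numbers for weaker inhibition), compound 2 holds the higher of the two numbers, with compound 1 its nearest neighbour. Going by the values given here, the single measured step is a 3.1-fold higher number from compound 1 to compound 2 (0.49 log units; beyond the scatter). Compound 3 `c1ccc2c(c1)CN[C@@H](CN(CCCCNC1CCCCC1)[C@H]1CCCc3cccnc31)C2` differs from compound 2 by cyclohexyl in place of (thian-4-yl)methyl on an amine nitrogen. Among the compounds with values here, that measured step changed the ring on a chain carbon, not the whole group on the amine nitrogen, so it bears only loosely on the present change; no direct precedent exists. A small move in either direction, or none beyond the scatter, seems likeliest. Compound 3 is expected at 90 nM (range 35 nM to 250 nM), an estimated step of a 1.3-fold higher number from compound 2 to compound 3 (0.11 log units; within the scatter).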

Compound 3, half-maximal inhibitory concentration: 75.2 nM
For compound 3 the middle estimate is 1.2-fold (0.08 log units) above the measured one; the range from low to high includes it.
By their numbers in this assay, from the lowest: compound 1; then compounds 2 and 3 (each within the scatter of the next).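

In this assay, cyclohexyl in place of (thian-4-yl)methyl on the amine nitrogen gives a 1.1-fold higher number from compound 2 to compound 3 (0.03 log units; within the scatter), so these two groups are not told apart at this position. Cyclohexyl in place of (pyridin-4-yl)methyl gives a 3.3-fold higher number from compound 1 to compound 3 (0.52 log units; beyond the scatter), which leaves compound 1 with the lowest number, and both groups with a non-aromatic ring behind it. No evidence is available to explain these steps. Open, going by these compounds, is whether a benzyl group on this amine nitrogen would read like compound 1 or like compound 3. A (pyridin-3-yl)methyl group would test whether the place of the ring nitrogen matters.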